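From Methyl to Chloro on the Shared Core

The source may hold more compounds than are shown below. What is called first, only, known or untested is meant among the compounds shown, and "the series" means these compounds.

Compound 2 `Cc1ccc(-c2csc(=N)n2CC(=O)N2CCOCC2)cc1` gives the lowest of the two numbers recorded in an assay on isolated protein for inhibition of leukotriene A-4 hydrolase (Homo sapiens) (on this read-out higher numbers stand for weaker inhibition and lower numbers for stronger inhibition), namely 3560 nM. Within the data shown here, its nearest neighbour is compound 1 `N=c1scc(-c2ccccc2)n1CC(=O)N1CCOCC1`, which in this assay gives 8650 nM; the one measured step, a 2.4-fold lower number from compound 1 to compound 2 (0.39 log units; beyond the scatter), adds a methyl in place of hydrogen on an aromatic carbon and is modest but beyond the scatter.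

Compound 3 `N=c1scc(-c2ccc(Cl)cc2)n1CC(=O)N1CCOCC1` differs from compound 2 by chloro in place of methyl on an aromatic carbon. Among the measured compounds shown here, no measured step exchanges methyl for chloro at this carbon, so the expectation rests only on the single recorded step, which shows that a one-heavy-atom group at this position of the shared core moved the number in this assay by a modest amount relative to the bare hydrogen of compound 1. A like-sized group in place of methyl is therefore expected to leave the number near that of compound 2, with any shift likely inside or barely beyond the scatter, in either direction.

Compound 3 is expected to give an estimated 2700 nM in this assay, within a range from 1000 nM to 7500 nM. The step that this estimate implies is a 1.3-fold lower number from compound 2 to compound 3 (0.12 log units; within the scatter).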

Compound 3, inhibition constant: 1060 nM
Beside the measured number, compound 3's estimate is 2.5-fold (0.41 log units) above it; low and high end bracket the measured number.
By their numbers in this assay, from the lowest: compound 3; then compound 2; then compound 1.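

Chloro in place of methyl gives a 3.4-fold lower number from compound 2 to compound 3 (0.53 log units; beyond the scatter) in this assay even though the two groups match in heavy atom count, hydrogen-bond donors and acceptors, and net charge, so at this aromatic carbon it matters which group stands there, not only that one does. Set against the bare hydrogen, chloro gives an 8.2-fold lower number from compound 1 to compound 3 (0.91 log units; beyond the scatter) and, with every step among these compounds beyond the scatter, the 4-chlorophenyl compound 3 is the strongest inhibitor of the three, ahead of the 4-methylphenyl compound 2 and the unsubstituted compound 1. Nothing at hand accounts for why chloro and methyl part here.

The compounds shown leave open whether a bromo, a methoxy or an amine at this carbon would extend the order running from hydrogen through methyl to chloro or break it. They also leave open whether the exchange of methyl for chloro would read the same way if a longer chain or a carboxylic acid were carried elsewhere on the shared core.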